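A few compounds are considered here, and "the series" means these few. Any claim that something is new, unique, unknown or untested is made for them only; others in the source may bear on it.

Measured compounds:
Compound 1 `CC(C)CN(CC(C)C)S(=O)(=O)c1ccc(NC(=O)C(C)(O)C(F)(F)F)cc1` gives > 30000 nM in an assay on a protein complex (Cavia porcellus) with sulfonylurea receptors; K-ATP channels (Homo sapiens) as the target; on this read-out higher numbers stand for weaker inhibition and lower numbers for stronger inhibition
Compound 2 `CC(O)(C(=O)Nc1ccc(-c2nn[nH]n2)cc1)C(F)(F)F` gives > 30000 nM in this assay

In this assay compound 1 gives only a limit, > 30000 nM, and not a number. Compound 2 gives only a limit as well in this assay, > 30000 nM. For the measured compounds named here, both values shown sit at the limit of > 30000 nM in this assay, at which 2 of the 2 values shown sit, so compound 2 stands nowhere below any other measured number, and there is no measured step between compound 1 and compound 2, which differ in more than one place; nothing can be said of the size of any change between them.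

Compound 3 `CC(O)(C(=O)Nc1ccc(S(N)(=O)=O)cc1)C(F)(F)F` arises from compound 2 by sulfamoyl in place of 2H-tetrazol-5-yl on an aromatic carbon. Going by the values given here, no measured step covers such a change, so for this assay no step beyond the usual scatter is expected, the estimated step being a step that the limit leaves unreadable from compound 2 to compound 3. For compound 3 the expected value in this assay is 40000 nM, with a range from 8000 nM to 200000 nM.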

Compound 3, half-maximal inhibitory concentration: 12800 nM
The estimate for compound 3 lay 3.1-fold (0.49 log units) above the measured number; low and high end bracket the measured number.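

In this assay compound 3 is the only one of the three to give a number, 12800 nM, so this position on the aromatic carbon can carry a group that gives a measurable value in the shared core. Sulfamoyl in place of 2H-tetrazol-5-yl gives an at least 2.3-fold lower number from compound 2 to compound 3 (0.36 log units; beyond the scatter), and amino in place of diisobutylamino on the sulfonyl sulfur gives an at least 2.3-fold lower number from compound 1 to compound 3 (0.36 log units; beyond the scatter). Both steps are only lower bounds, as the far end of each is a limit: the limit of > 30000 nM in this assay, at which 2 of the 3 values shown sit.

Going by these compounds, the true size of either step stays open, since neither compound 1 nor compound 2 has a number to set against compound 3. Also open, on these data alone, is how a methylamino group on the sulfonyl sulfur, or a carboxylic acid on the same aromatic carbon, would compare with compound 3.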